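Swapping a trifluoromethyl for an aminomethyl on a GPR88 agonist

A few compounds are considered here, and "the series" means these few. Any claim that something is new, unique, unknown or untested is made for them only; others in the source may bear on it.

Measured compounds:
- compound 1, `CC[C@H](C)[C@H](N)CN(C(=O)[C@@H]1C[C@H]1c1ccccn1)c1ccc(-c2ccccc2)cc1`: 130 nM
- compound 2, `COc1cccc(-c2ccc(N(C[C@@H](N)CC(C)C)C(=O)[C@@H]3C[C@H]3c3ccccc3)cc2)c1`: 1100 nM
- compound 3, `CC[C@H](C)[C@H](N)CN(C(=O)[C@@H]1C[C@H]1c1ccccc1)c1ccc(-c2ccc(C(F)(F)F)cc2)cc1`: 340 nM

In a functional assay for agonist activity at G protein-coupled receptor 88 (Homo sapiens), read by HTRF and cAMP accumulation (a higher number here means that more compound is needed for the effect, a lower number that less compound is needed), compound 3 sits second highest of the three numbers, well apart from both compound 1 and compound 2. The next compound, compound 4, `CC[C@H](C)[C@H](N)CN(C(=O)[C@@H]1C[C@H]1c1ccccc1)c1ccc(-c2ccc(CN)cc2)cc1`, has not yet been measured. Compared with compound 3 it carries one change: aminomethyl in place of trifluoromethyl on an aromatic carbon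

Among the measured compounds shown here, no pair of measured compounds differs in just one place, so there is no directly comparable step to lean on. The change replaces a group with no hydrogen-bond donor or acceptor by one that carries one of each, at the far end of the shared core. For compound 4 the expectation in this assay is a modest rise, a 1.5-fold higher number from compound 3 to compound 4 (0.17 log units; within the scatter), giving an estimated 500 nM within 150 nM to 1800 nM.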

Compound 4, half-maximal effective concentration: > 30000 nM
Compound 4: only a limit was reported; the forecaster's own chance of this, stated with the estimate: 5%; middle value at least 60-fold (1.77 log units) away from the limit.
By their numbers in this assay, from the lowest: compound 1; then compound 3; then compound 2. At a limit, above all of these: compound 4.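

Compound 4 gave no number, only a limit of the assay: the limit of > 30000 nM in this assay, at which 1 of the 4 values shown sits. In this assay, among the compounds shown here, the change gives an at least 88-fold higher number from compound 3 to compound 4 (1.94 log units; beyond the scatter), the first step here that differs in one place. It shows that this position, para to a large group, does not accept every small group: aminomethyl in place of trifluoromethyl is enough to take the compound out of the measurable range. The compounds shown leave open whether a methyl, a hydroxymethyl or a carboxylic acid here would keep the effect, and so whether the loss belongs to the arrival of the amine or to the departure of trifluoromethyl.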